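The source may hold more compounds than are shown below. What is called first, only, known or untested is meant among the compounds shown, and "the series" means these compounds.

Of the compounds shown here, three that share one core have been measured in a functional assay on MCF7 cells (Homo sapiens) for cytotoxicity, read by MTT assay, with a stated time of 24 h, tested at 6.4 ug/mL; on this read-out higher numbers stand for a stronger effect at the one concentration tested and lower numbers for a weaker effect. Compound 1 `Cn1c(-c2ccc(NC(=O)CSc3nc4ccccc4o3)cc2)nc(-c2ccccc2)c1-c1ccccc1` gives 42.3%. Compound 2 `Cc1ccc2oc(SCC(=O)Nc3ccc(-c4nc(-c5ccccc5)c(-c5ccccc5)n4C)cc3)nc2c1` gives 24.6%, and compound 3 `Cn1c(-c2ccc(NC(=O)CSC3=NCCS3)cc2)nc(-c2ccccc2)c1-c1ccccc1` gives 18.6%. Among these three numbers compound 2 stands second highest: compound 3 is its nearest neighbour, within the scatter, while compound 1 lies further off, beyond the scatter, as the step of a number 17.7 percentage points lower from compound 1 to compound 2 (beyond the scatter) shows.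

Compound 4 `CN1CCN(CC(=O)Nc2ccc(-c3nc(-c4ccccc4)c(-c4ccccc4)n3C)cc2)CC1` has not yet been measured. It differs from compound 2 in one place: 4-methylpiperazin-1-yl in place of (5-methyl-1,3-benzoxazol-2-yl)sulfanyl on a saturated chain carbon bound to a carbonyl carbon.

For the measured compounds named here, two measured steps bear on this. In both, a group holding one five-membered aromatic ring with 2 hetero atoms and one six-membered aromatic ring of carbon only left the sulfur and a smaller non-aromatic ring entered: a number 23.7 percentage points lower from compound 1 to compound 3 (beyond the scatter) and a number 6 percentage points lower from compound 2 to compound 3 (within the scatter). Here the whole sulfanyl group leaves and a six-membered non-aromatic ring with 2 hetero atoms enters. On that basis a step downward, or none beyond the scatter, is expected, a number 9.6 percentage points lower from compound 2 to compound 4 (within the scatter). Compound 4 is therefore estimated at 15%, within a range from 4% to 30%.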

Compound 4, a percentage reported as activity, at one concentration (the size of the read-out at that concentration, not a potency): 28.6%
Beside the measured number, compound 4's estimate is 13.6 percentage points below it; measured number inside the range.
By their numbers in this assay, from the lowest: compounds 3, 2 and 4 (each within the scatter of the next); then compound 1.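

At this position, on a saturated chain carbon bound to a carbonyl carbon, the sulfur link need not stay: putting 4-methylpiperazin-1-yl in place of (5-methyl-1,3-benzoxazol-2-yl)sulfanyl in this assay gives a number 4 percentage points higher from compound 2 to compound 4 (within the scatter), and the other comparison with a non-aromatic ring gives a number 10 percentage points higher from compound 3 to compound 4 (within the scatter). Only the group of compound 1, (1,3-benzoxazol-2-yl)sulfanyl, stands apart from the piperazine, with a number 13.7 percentage points lower from compound 1 to compound 4 (beyond the scatter), so this sulfur-free group matches the groups of compound 2 and compound 3 but not that of compound 1. Nothing measured here accounts for these numbers.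

Still open, on these data alone, is whether morpholin-4-yl, or a longer chain carrying the 4-methylpiperazin-1-yl group, would stay level with compound 4 or come closer to compound 1. Each compound is also read at a single concentration, so these numbers say nothing about potency.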